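This account rests on a few compounds, and the source may have more. Where it says the series, first, only, none or still open, it means among the compounds named here.

In a functional assay on SW48 cells (Homo sapiens) for antiproliferative activity, read by MTT assay, with a stated time of 72 h (a higher number here means a weaker inhibitor, a lower number a stronger inhibitor), compound 1 `COc1ccc([C@H]2[C@H](NC(=O)c3ccc(Cl)cc3)C(=O)N2c2cc(OC)c(OC)c(OC)c2)cc1O` gives 271 nM, and compound 2 `COc1ccc([C@H]2[C@H](NC(=O)c3ccc(F)cc3)C(=O)N2c2cc(OC)c(OC)c(OC)c2)cc1O` gives 384 nM. These values lie within the scatter of each other, so compound 2 cannot be told apart from compound 1. Compound 3 `COc1ccc([C@H]2[C@H](NC(=O)c3cc(OC)c(OC)c(OC)c3)C(=O)N2c2cc(OC)c(OC)c(OC)c2)cc1O` differs from compound 2 at one place: 3,4,5-trimethoxyphenyl in place of 4-fluorophenyl on a carbonyl carbon. For the measured compounds named here, the only measured step, a 1.4-fold higher number from compound 1 to compound 2 (0.15 log units; within the scatter), swaps one halogen for another, so it offers only weak guidance for this much bigger exchange. No step beyond the scatter is therefore expected in this assay, with wide uncertainty. The estimated step is a 1.0-fold higher number from compound 2 to compound 3 (0.02 log units; within the scatter). Compound 3 is expected at 400 nM, within an estimated range of 100 nM to 1600 nM.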

Compound 3, half-maximal inhibitory concentration: 564 nM
The estimate for compound 3 lay 1.4-fold (0.15 log units) below the measured number; the measured number falls inside the stated range.
By their numbers in this assay, from the lowest: compounds 1, 2 and 3 (each within the scatter of the next, the first and the last beyond it).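

In this assay the carbonyl carbon accepts the larger 3,4,5-trimethoxyphenyl group in place of 4-fluorophenyl with no clear change, as the step of a 1.5-fold higher number from compound 2 to compound 3 (0.17 log units; within the scatter) stays within the scatter. Set against 4-chlorophenyl, the same group gives the first step here to pass the scatter, though only modestly: a 2.1-fold higher number from compound 1 to compound 3 (0.32 log units; beyond the scatter). Nothing available explains either step. Still open, as far as these compounds go, is what a carbonyl carbon bearing a non-aromatic group, such as a longer alkyl chain, would give. So is the effect of an amine or a carboxylic acid on the aromatic ring.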